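Trading 1,3-thiazol-2-yl for 1-methyl-1H-pyrazol-4-yl on a Shared Core

The compounds below may be only part of what the source reports. "The series", "measured", "known", "first", "only" and "open" are said of these compounds alone.

Compound 1 `COc1c(Cl)ccc2c1CCC2c1ncc[nH]1`: 24%
Compound 2 `c1cc(-c2nccs2)c2c(c1)C(c1ncc[nH]1)CC2`: 64%
Compound 3 `Clc1ccc2c(c1-c1ccn[nH]1)CCC2c1ncc[nH]1`: 40%

In a functional assay on CHO cells for agonist activity at Alpha-1A adrenergic receptor (Homo sapiens), read by FLIPR and calcium flux (on this read-out higher numbers stand for larger maximal responses and lower numbers for smaller maximal responses), compound 2 stands highest of the three measured compounds; compound 3 comes nearest and compound 1 lies furthest, both beyond the scatter. Going by the values given here, the one measured step that changes a single place, a number 16 percentage points higher from compound 1 to compound 3 (beyond the scatter), replaces a small group with a five-membered aromatic ring and raises the response modestly. Compound 4 `Cn1cc(-c2cccc3c2CCC3c2ncc[nH]2)cn1` is built from compound 2 by the change (1-methyl-1H-pyrazol-4-yl in place of 1,3-thiazol-2-yl on an aromatic carbon). Here one five-membered aromatic ring with two hetero atoms gives way to another of the same kind, a swap no measured step covers, so the step from compound 1 to compound 3 bears on it only loosely. The estimate for compound 4 is therefore close to compound 2, with a wide range: an expected step of a number 9 percentage points lower from compound 2 to compound 4 (within the scatter), likely within the scatter. Compound 4 is expected to reach 55%, between 35% and 75%.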

Compound 4, largest response reached (Emax), in percent of the reference or control that the assay uses: 12%
Compound 4: middle estimate off by 43 percentage points, on the high side, outside the stated range (below it).
By their numbers in this assay, from the lowest: compound 4; then compound 1; then compound 3; then compound 2.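

In this assay, the change on this aromatic carbon gives a number 52 percentage points lower from compound 2 to compound 4 (beyond the scatter). Going by these compounds alone, the earlier compounds showed only that a five-membered aromatic ring could take the place of methoxy, whereas this pair shows that the choice between two such rings matters greatly, even though both carry 2 hetero atoms, 0 hydrogen-bond donors and 2 hydrogen-bond acceptors and have no net charge. So those shared counts do not settle the response here, and nothing at hand accounts for the size of this step.

The new ring differs from the old one in its atoms, its methyl group and its point of attachment at once, so the pair cannot show which of these matters. Going by these compounds, how a phenyl ring or a primary amide on this same carbon would read also remains open.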